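Methoxy in place of hydrogen: from compound 3 to compound 4

The compounds below may be only part of what the source reports. "The series", "measured", "known", "first", "only" and "open" are said of these compounds alone.

Three compounds of the series carry numbers in a functional assay on MCF7 cells (Homo sapiens) for inhibition, read by MTT assay, with a stated time of 72 h; on this read-out lower numbers stand for stronger inhibition and higher numbers for weaker inhibition. Compound 1 `O=C(Nc1ccc(Oc2ccnc3[nH]ccc23)cc1)c1cn(-c2ccc(Cl)cc2)c2ccccc2c1=O` gives 1590 nM in this assay. Compound 2 `COc1ccc(-n2cc(C(=O)Nc3ccc(Oc4ccnc5[nH]ccc45)cc3)c(=O)c3ccccc32)cc1` gives 4650 nM. Compound 3 `Cn1ccc2c(Oc3ccc(NC(=O)c4cn(-c5ccccc5)c5ccccc5c4=O)cc3F)ccnc21` gives 2790 nM, which lies within the usual scatter of both compound 1 and compound 2, so the three numbers cannot be ordered with any confidence. Within the data shown here, the one single-point step measured so far, a 2.9-fold higher number from compound 1 to compound 2 (0.47 log units; beyond the scatter), is methoxy in place of chloro on an aromatic carbon.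

Compound 4 `COc1ccc(-n2cc(C(=O)Nc3ccc(Oc4ccnc5c4ccn5C)c(F)c3)c(=O)c3ccccc32)cc1` has not been measured. It differs from compound 3 by methoxy in place of hydrogen on an aromatic carbon. Among the measured compounds shown here, no measured step exchanges hydrogen for methoxy; the step from compound 1 to compound 2 is the only one that introduces methoxy at the same place, and there the methoxy compound carried the higher number, though relative to chloro rather than to hydrogen. For the measured compounds named here, that step is the sole bearing evidence and is carried over with caution. Compound 4 is therefore expected to give a modestly higher number than compound 3, a step of about a 1.8-fold higher number from compound 3 to compound 4 (0.25 log units; within the scatter). The estimate for compound 4 in this assay is 5000 nM, with a range from 2000 nM to 12500 nM.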

Compound 4, half-maximal inhibitory concentration: 6720 nM
Beside the measured number, compound 4's estimate is 1.3-fold (0.13 log units) below it; the range from low to high includes it.
By their numbers in this assay, from the lowest: compounds 1, 3, 2 and 4 (each within the scatter of the next, the first and the last beyond it).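

In this assay, among these compounds, a 2.4-fold higher number from compound 3 to compound 4 (0.38 log units; beyond the scatter) gives the first reading of methoxy against hydrogen at this place, the change from phenyl to 4-methoxyphenyl, whereas the earlier compounds set methoxy only against chloro. Taken with a 2.9-fold higher number from compound 1 to compound 2 (0.47 log units; beyond the scatter), methoxy carries the higher number in both single-change pairs, once on the core of compound 1 and once on the core of compound 3, and neither pair goes against this, although the pattern reaches only these four compounds. Nothing measured on these compounds accounts for either step.

Going by these compounds, compound 1 and compound 3 differ in more than one place, so it remains open how hydrogen and chloro rank on a single core, and whether the two methoxy steps would hold on exchanged cores. Also open, on these data alone, is how an amine, a hydroxyl or a carboxylic acid would read at this place on the phenyl ring, and whether a longer chain such as ethoxy would follow methoxy.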